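The source may report more compounds than this note shows. Statements on the series, on what has been measured and on what is new or still open speak of the compounds shown alone.

Compound 1, `CN1CCN(c2ccc(S(=O)(=O)Oc3cccc(F)c3)cc2)C1=O`, and compound 2, `CN1CCN(c2ccc(S(=O)(=O)Oc3cccc(Cl)c3)cc2)C1=O`, share one core, and in a functional assay on M21 cells (Homo sapiens) for antiproliferative activity, read by sulforhodamine B assay, with a stated time of 48 h (a higher number here means a weaker inhibitor, a lower number a stronger inhibitor), compound 1 gives 5800 nM while compound 2 gives 1600 nM. The two differ by chloro in place of fluoro on an aromatic carbon, and that change made a 3.6-fold lower number from compound 1 to compound 2 (0.56 log units; beyond the scatter).

Compound 3, `CCCN1CCN(c2ccc(S(=O)(=O)Oc3ccc(F)cc3)cc2)C1=O`, carries a different core; how the core of compound 3 differs from the core of compound 1 is not broken down here. In this assay compound 3 gives 14000 nM, the highest number among the three measured compounds, above compound 1 and further still above compound 2.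

Compound 4, `CCCN1CCN(c2ccc(S(=O)(=O)Oc3ccc(Cl)cc3)cc2)C1=O`, is not yet measured. It differs from compound 3 by chloro in place of fluoro on an aromatic carbon. Going by the values given here, this is the same kind of change as the one from compound 1 to compound 2, but not the same: in compound 2 the chloro sits meta to a large group, while in compound 4 it sits para to a large group, and the cores differ as well. Among the compounds with values here, the one measured example of this kind of change is the step from compound 1 to compound 2, so the expectation rests on that step alone, with the shift in place and core adding uncertainty.

Compound 4 is therefore expected to show a step of a 3.1-fold lower number from compound 3 to compound 4 (0.49 log units; beyond the scatter) in this assay, a little smaller than the measured one because a 3.6-fold lower number from compound 1 to compound 2 (0.56 log units; beyond the scatter) was seen with the chloro in a different place. Compound 4 is estimated at 4500 nM, with a range from 1500 nM to 12000 nM.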

Compound 4, half-maximal inhibitory concentration: 34000 nM
Beside the measured number, compound 4's estimate is 7.6-fold (0.88 log units) below it; measured number outside the range, above it.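

In this assay, chloro in place of fluoro on an aromatic carbon did not carry over from one core to the other, giving a 2.4-fold higher number from compound 3 to compound 4 (0.39 log units; beyond the scatter), so the step runs the opposite way to the earlier one: the same change on two cores in this assay, a 3.6-fold lower number (0.56 log units; beyond the scatter) from compound 1 to compound 2 and a 2.4-fold higher number (0.39 log units; beyond the scatter) from compound 3 to compound 4, 8.8-fold (0.94 log units) apart, beyond the scatter of two such steps

This shows that, across these two pairs, neither the size nor the direction of the step from fluoro to chloro can be taken from one pair and applied to the other. It does not show what reverses the step, since the pairs differ in more than the core: in compound 4 the chloro sits para to a large group, which is not where it sits in compound 2, and two steps cannot separate that difference in place from the difference in core.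

The compounds shown leave open whether the reversal follows the core or the place of the halogen, a question that each halogen in both places on both cores would settle. They also leave open how a bromo or methoxy group in the same place, or a butyl chain on the core in place of the propyl chain of compound 3, would read in this assay.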